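The compounds below may be only part of what the source reports. "The series", "measured", "known", "first", "only" and "open" are said of these compounds alone.

Compound 3 `CN(CCNCc1cn(Cc2ccc(Br)cc2)nn1)CCNc1ccnc2cc(Cl)ccc12` carries a 4-bromobenzyl group on an aromatic nitrogen of a five-membered aromatic ring, and in a functional assay on NCI-H460 cells (Homo sapiens) for antiproliferative activity, read by sulforhodamine B assay, with a stated time of 72 h (on this read-out higher numbers stand for weaker inhibition and lower numbers for stronger inhibition), compound 3 gives 12000 nM. Among the three measured compounds this is the lowest number. Compound 2 `CN(CCNCc1cn(-c2ccc(Br)cc2)nn1)CCNc1ccnc2cc(Cl)ccc12` gives 15000 nM, and compound 1 `C#CCNCCN(C)CCNc1ccnc2cc(Cl)ccc12` gives 69000 nM. The step of a 1.3-fold lower number from compound 2 to compound 3 (0.10 log units; within the scatter) was small, whereas the gap to compound 1 lies beyond the scatter.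

Compound 4 `CN(CCNCc1cn(-c2ccnc3cc(Cl)ccc23)nn1)CCNc1ccnc2cc(Cl)ccc12` is not yet measured. It differs from compound 3 in one place: 7-chloroquinolin-4-yl in place of 4-bromobenzyl on an aromatic nitrogen. Among the compounds with values here, the only measured step that touches the same aromatic nitrogen is a 1.3-fold lower number from compound 2 to compound 3 (0.10 log units; within the scatter), which shows that exchanging one group for another there shifted the number little. That step swapped two closely related bromine-bearing groups, while the change to compound 4 brings in a second 7-chloroquinolin-4-yl group, the same kind of ring system that already sits in the shared core. Within the data shown here, no measured pair shows this kind of exchange, so the expectation leans on the one step available and stays broad. Compound 4 is expected to give about 8000 nM, within a range from 2500 nM to 25000 nM. The step of a 1.5-fold lower number from compound 3 to compound 4 (0.18 log units; within the scatter) that this estimate means is expected to stay near or only modestly beyond the scatter.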

Compound 4, half-maximal inhibitory concentration: 16000 nM
Beside the measured number, compound 4's estimate is 2.0-fold (0.30 log units) below it, and the stated range covers the measured number.
By their numbers in this assay, from the lowest: compounds 3, 2 and 4 (each within the scatter of the next); then compound 1.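

In this assay the exchange of 4-bromobenzyl for 7-chloroquinolin-4-yl on the aromatic nitrogen gives a 1.3-fold higher number from compound 3 to compound 4 (0.12 log units; within the scatter) and the exchange of 4-bromophenyl for the same group gives a 1.1-fold higher number from compound 2 to compound 4 (0.03 log units; within the scatter) in the same read-out. Within the data shown here, the earlier step compared only two bromine-bearing groups, whereas these steps show that a quite different group, with 11 heavy atoms in place of 8, a second ring and a hydrogen-bond acceptor, also leaves the number within the scatter at this position. Nothing available explains why these three groups give such similar numbers.

All three groups shown on this nitrogen carry an aromatic ring of carbon, so it remains open whether a simple amine, a carboxylic acid or a longer chain ending in one of these would move the number beyond the scatter. Going by these compounds, it also remains open whether other groups at this position could take the number far from the narrow band seen for compound 2, compound 3 and compound 4, or whether this nitrogen has little influence on the read-out.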